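From hydroxymethyl to formyl on the shared core

A few compounds are considered here, and "the series" means these few. Any claim that something is new, unique, unknown or untested is made for them only; others in the source may bear on it.

In a functional assay on QG-56 cells (Homo sapiens) for antiproliferative activity (a lower number here means a stronger inhibitor, a higher number a weaker inhibitor), compound 1 `Cn1cncc1C(O)(c1ccc(C#N)cc1)c1cc2cc(C#N)cc(-c3ccccc3)c2o1` gives 14.5 nM and compound 3 `COc1cccc(-c2cc(CO)cc3cc(C(O)(c4ccc(C#N)cc4)c4cncn4C)oc23)c1` gives 16.8 nM as two values within the scatter of each other. Compound 2 `Cn1cncc1C(O)(c1ccc(C(=O)OC(C)(C)C)cc1)c1cc2cc([N+](=O)[O-])cc(-c3ccccc3)c2o1` at 6250 nM lies far higher than compound 3, which thus holds the second highest number of the three. For the measured compounds named here, compound 4 `COc1cccc(-c2cc(C=O)cc3cc(C(O)(c4ccc(C#N)cc4)c4cncn4C)oc23)c1` is compound 3 with formyl in place of hydroxymethyl on an aromatic carbon and no measured pair isolates this change. Compound 1, which has a nitrile on that carbon and differs elsewhere too, still gives 14.5 nM in the same range, so in this assay only a small step towards a weaker inhibitor is expected, probably within the scatter. The expected move is a 1.3-fold higher number from compound 3 to compound 4 (0.12 log units; within the scatter) in this estimate. Compound 4 is estimated at 22 nM with an expected range of 7 nM to 70 nM around it.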

Compound 4, half-maximal inhibitory concentration: 15.2 nM
The estimate for compound 4 lay 1.4-fold (0.16 log units) above the measured number; the measured number falls inside the stated range.
By their numbers in this assay, from the lowest: compounds 1, 4 and 3 (each within the scatter of the next); then compound 2.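

In this assay, for the compounds shown here, this is the first pair that isolates the change at this aromatic carbon, and it gives a 1.1-fold lower number from compound 3 to compound 4 (0.04 log units; within the scatter), within the scatter. Formyl in place of hydroxymethyl removes the hydrogen-bond donor at this position without a step beyond the scatter, so that donor shows no measurable contribution on this shared core in this assay. Nothing available accounts for this result. Going by these compounds, whether an amine, a carboxylic acid or a longer chain such as hydroxyethyl on this carbon would also be tolerated remains open.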